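Chloro added to a compound at the assay limit

This account rests on a few compounds, and the source may have more. Where it says the series, first, only, none or still open, it means among the compounds named here.

Measured so far in a functional assay on AGS cells (Homo sapiens) for antiproliferative activity, read by MTT assay, with a stated time of 48 h (on this read-out lower numbers stand for stronger inhibition of growth and higher numbers for weaker inhibition of growth), are two compounds:
- Compound 1 `COc1ccc(N(C)c2ncnc3[nH]cnc23)cc1` gives > 100000 nM as a limit
- Compound 2 `COc1ccc(N(C)c2ncnc3c2ncn3C)cc1` gives > 100000 nM as a limit

Compound 1 therefore stands at a limit and not at a number, and the record so far is the limit of > 100000 nM in this assay, at which 2 of the 2 values shown sit, in all. Compound 3 `COc1ccc(N(C)c2nc(Cl)nc3[nH]cnc23)cc1` differs from compound 1 by one change: chloro in place of hydrogen on an aromatic carbon. Among the compounds with values here, the only measured step is a step that the two limits leave unreadable from compound 1 to compound 2 and it is a methyl on an aromatic nitrogen, not a chloro on an aromatic carbon. It offers no size to carry over. A move toward stronger growth inhibition in this assay is expected only tentatively. The expected step is an at least 10-fold lower number from compound 1 to compound 3 (1.00 log units; beyond the scatter) and it remains wide. Compound 3 is estimated at 10000 nM with a range from 500 nM to 100000 nM expected.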

Compound 3, concentration for 50% growth inhibition: 30000 nM
Compound 3: middle estimate off by 3.0-fold (0.48 log units), on the low side; measured number inside the range.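

Chloro in place of hydrogen on an aromatic carbon, between two ring nitrogen atoms, brings an at least 3.3-fold lower number from compound 1 to compound 3 (0.52 log units; beyond the scatter) in this assay. This shows that a change at this position can register on this read-out, which the earlier pair could not show. How large the step really is stays unknown, and compound 3 is the only compound with a number: the limit of > 100000 nM in this assay, at which 2 of the 3 values shown sit.

As far as these compounds go, whether an amine or a nitrile on this carbon would do more or less than chloro remains open. So does whether chloro would bring a similar step to compound 2.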